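Cytotoxicity notes: biphenyl amides and a bromo analogue

The compounds below may be only part of what the source reports. "The series", "measured", "known", "first", "only" and "open" are said of these compounds alone.

The series shares an ethyl ester chain on an ether-linked benzylic amide with an isopropyl group on nitrogen; compound 1 `CCOC(=O)CCCCCOc1cccc(CN(C(=O)c2ccc(-c3cccc(-c4nnc(C)o4)c3)cc2)C(C)C)c1` carries a 5-methyl-1,3,4-oxadiazol-2-yl group on the outer ring, while compound 2 `CCOC(=O)CCCCCOc1cccc(CN(C(=O)c2ccc(-c3cccc(C(F)(F)F)c3)cc2)C(C)C)c1` carries a trifluoromethyl in its place. In an ADME assay on Raji cells (Homo sapiens) for cytotoxicity, read by CellTiter-Glo and resazurin assay, with a stated time of 72 h (a higher number here means that more compound is needed for the effect, a lower number that less compound is needed), compound 1 gives > 26000 nM, a limit of the assay rather than a number. In this assay compound 2 likewise gives > 26000 nM, again a limit. The step that the two limits leave unreadable from compound 1 to compound 2 therefore cannot be sized; both values sit at the limit of > 26000 nM in this assay, at which 2 of the 2 values shown sit, and compound 2 stands at that limit with no readable difference from compound 1.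

Compound 3 `CCOC(=O)CCCCCOc1cccc(CN(C(=O)c2ccc(Br)cc2)C(C)C)c1` drops the outer ring altogether: bromo in place of 3-(trifluoromethyl)phenyl on an aromatic carbon. Within the data shown here, no measured step bears directly on this change; the one step available is unreadable, and both known values are limits. In this assay the expected step is a step that the limit leaves unreadable from compound 2 to compound 3, none beyond the scatter, since nothing measured suggests a cytotoxic signal emerging. Compound 3 is expected to give 30000 nM, with a range from 10000 nM to 100000 nM, most likely again reported only as a limit.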

Compound 3, half-maximal effective concentration: > 26000 nM
Compound 3 gave a limit, no number; the forecaster's own chance of this, stated with the estimate: 80%; the middle value lies beyond the limit too.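

In this assay compound 3 gives > 26000 nM, a limit and not a number. No step among compound 1, compound 2 and compound 3 can be read: the limit of > 26000 nM in this assay, at which 3 of the 3 values shown sit.

Left open is the concentration at which any of these three compounds would show an effect in this assay, and whether exchanging these groups changes it at all.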